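Bromophenyl Replaces Benzothiazole on the Amide Nitrogen

The source may report more compounds than this note shows. Statements on the series, on what has been measured and on what is new or still open speak of the compounds shown alone.

Compound 2 `Cc1cccc2sc(NC(=O)COc3ccc4cc(/C=C5/SC(=O)NC5=O)ccc4c3)nc12` carries a 4-methyl-1,3-benzothiazol-2-yl group on the amide-type nitrogen of the shared core. In an assay on isolated protein for inhibition of histone deacetylase 8 (Homo sapiens), with a stated time of 1 h (on this read-out higher numbers stand for weaker inhibition and lower numbers for stronger inhibition), compound 2 gives 5800 nM, the only full number shown. Compound 1 `O=C(COc1ccc2cc(/C=C3/SC(=O)NC3=O)ccc2c1)Nc1cccc(C(F)(F)F)c1` bears a 3-(trifluoromethyl)phenyl group on that same nitrogen. For compound 1 this assay reports only a limit, > 50000 nM. Among the compounds with values here, the single measured step, an at least 8.6-fold lower number from compound 1 to compound 2 (0.93 log units; beyond the scatter), thus shows an at least modest gain when a six-membered ring of carbon only gives way to the benzothiazole. Compound 3 `O=C(COc1ccc2cc(/C=C3/SC(=O)NC3=O)ccc2c1)Nc1ccc(Br)cc1` moves in the opposite direction: 4-bromophenyl in place of 4-methyl-1,3-benzothiazol-2-yl on an amide-type nitrogen. Because the step from compound 1 to compound 2 was an at least 8.6-fold lower number from compound 1 to compound 2 (0.93 log units; beyond the scatter), returning to a six-membered aromatic ring of carbon only is expected to weaken inhibition, so a step of a 5.2-fold higher number from compound 2 to compound 3 (0.71 log units; beyond the scatter) is expected. Compound 3 is therefore estimated at 30000 nM, within a range from 8000 nM to 100000 nM. A reading at the limit of > 50000 nM in this assay, at which 1 of the 2 values shown sits, cannot be excluded.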

Compound 3, half-maximal inhibitory concentration: 16000 nM
For compound 3 the middle estimate is 1.9-fold (0.27 log units) above the measured one; the measured number falls inside the stated range.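

In this assay, a six-membered aromatic ring of carbon only on the amide-type nitrogen does not rule out measurable inhibition: 4-bromophenyl in place of 3-(trifluoromethyl)phenyl gives an at least 3.1-fold lower number from compound 1 to compound 3 (0.49 log units; beyond the scatter). Going by these compounds, compound 1 is recorded only as a limit, so the full size of that step stays unknown: the limit of > 50000 nM in this assay, at which 1 of the 3 values shown sits. The 4-methyl-1,3-benzothiazol-2-yl group still keeps an edge over 4-bromophenyl, with a 2.8-fold higher number from compound 2 to compound 3 (0.44 log units; beyond the scatter), so the outcome at this nitrogen depends on more than ring type alone.

The names 4-bromophenyl and 3-(trifluoromethyl)phenyl differ both in the group and in where it sits, and these two changes cannot be separated here. On these data alone, how a plain phenyl group, or a phenyl ring carrying a methoxy group or an amine, would read remains open.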